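The source may hold more compounds than are shown below. What is called first, only, known or untested is meant among the compounds shown, and "the series" means these compounds.

Three compounds have so far been measured in a functional assay on HL-60 cells (Homo sapiens) for cytotoxicity, read by WST assay, with a stated time of 48 h; on this read-out lower numbers stand for an effect already at smaller amounts and higher numbers for an effect only at larger amounts of compound:

compound 1 `CCOc1ccccc1C[C@H]1COC(=O)[C@@H]1Cc1ccc(Cl)c(Cl)c1`: 15000 nM
compound 2 `CCCCOc1ccccc1C[C@H]1COC(=O)[C@@H]1Cc1ccc(Cl)c(Cl)c1`: 10000 nM
compound 3 `CCc1ccc(C[C@H]2COC(=O)[C@@H]2Cc2ccc(Cl)c(Cl)c2)cc1`: 16000 nM

Compound 1 and compound 2 share one core, while compound 3 is built on another; the difference between the two cores is not broken down here. From compound 1 to compound 2 the change is ethyl in place of hydrogen on a saturated chain carbon, two bonds along the chain from an oxygen on an aromatic ring, and in this assay it gave a 1.5-fold lower number from compound 1 to compound 2 (0.18 log units; within the scatter).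

Compound 4 `CCCCc1ccc(C[C@H]2COC(=O)[C@@H]2Cc2ccc(Cl)c(Cl)c2)cc1` has not yet been measured. It differs from compound 3 by ethyl in place of hydrogen on a saturated chain carbon, two bonds along the chain from an aromatic carbon. This is the same kind of change as before, not the same: in compound 1 the carbon that gains the ethyl sits two bonds along the chain from an oxygen on an aromatic ring, in compound 3 two bonds along the chain from an aromatic carbon.

Going by the values given here, the one comparable step, a 1.5-fold lower number from compound 1 to compound 2 (0.18 log units; within the scatter), stayed within the scatter, so a similarly small step is expected here: a 1.5-fold lower number from compound 3 to compound 4 (0.16 log units; within the scatter). Compound 4 is therefore estimated to give 11000 nM in this assay, most likely between 5000 nM and 25000 nM.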

Compound 4, half-maximal effective concentration: 9400 nM
Beside the measured number, compound 4's estimate is 1.2-fold (0.07 log units) above it; measured number inside the range.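

In this assay, ethyl in place of hydrogen on a saturated chain carbon, two bonds along the chain from an aromatic carbon, gave a 1.7-fold lower number from compound 3 to compound 4 (0.23 log units; within the scatter). Set beside the earlier step, the change behaves alike on the two cores: the same change on two cores in this assay, a 1.5-fold lower number (0.18 log units; within the scatter) from compound 1 to compound 2 and a 1.7-fold lower number (0.23 log units; within the scatter) from compound 3 to compound 4, 1.1-fold (0.05 log units) apart, within the scatter of two such steps

So in this small set the change carries over from one core to the other as a similarly small step, but each step on its own stays within the scatter, and two cores cannot show that it would hold on a third or that the added ethyl truly lowers the number.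

The compounds shown leave open whether a longer chain in the same place would move the number beyond the scatter. They also leave open what a chain ending in an amine or a carboxylic acid would do there.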